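This account rests on a few compounds, and the source may have more. Where it says the series, first, only, none or still open, it means among the compounds named here.

Compound 1 `CC(C)=CC[C@@H](OC[C@@H](C)O)C1=CC(=O)c2c(O)ccc(O)c2C1=O` gives 22500 nM in a functional assay on HeLa cells (Homo sapiens) for cytotoxicity, read by MTT assay; a lower number here means a stronger inhibitor, a higher number a weaker inhibitor. Compound 2 `CC(=O)OCCO[C@H](CC=C(C)C)C1=CC(=O)c2c(O)ccc(O)c2C1=O` gives 41500 nM and stands second highest of the three numbers, nearest to compound 3 `CCCCC(CC(=O)O[C@H](CC=C(C)C)C1=CC(=O)c2c(O)ccc(O)c2C1=O)OC(C)=O`, which gives 73500 nM, and furthest from compound 1. Within the data shown here, the step of a 1.8-fold higher number from compound 1 to compound 2 (0.27 log units; within the scatter) is the one measured change at this position. Compound 4 `CC(C)=CC[C@@H](OC(=O)C1CCOC1)C1=CC(=O)c2c(O)ccc(O)c2C1=O` carries the change ((oxolan-3-yl)carbonyl in place of 2-acetoxyethyl on an oxygen on a saturated carbon). Among the measured compounds shown here, the only step that bears on it is the one just named, and it was small; the gap between compound 2 and compound 3, which carries an ester at the same oxygen, is also small. Compound 4 is therefore expected to show no step beyond the scatter, a 1.2-fold higher number from compound 2 to compound 4 (0.08 log units; within the scatter), with an estimated 50000 nM and a range from 20000 nM to 125000 nM.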

Compound 4, half-maximal inhibitory concentration: 73500 nM
For compound 4 the middle estimate is 1.5-fold (0.17 log units) below the measured one; measured number inside the range.
By their numbers in this assay, from the lowest: compounds 1, 2, 3 and 4 (each within the scatter of the next, the first and the last beyond it).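

Placing (oxolan-3-yl)carbonyl on this oxygen in place of 2-acetoxyethyl gives a 1.8-fold higher number from compound 2 to compound 4 (0.25 log units; within the scatter) and, read at the carbonyl carbon, oxolan-3-yl in place of 2-acetoxyhexyl gives no change at the digits printed from compound 3 to compound 4 (within the scatter), so this five-membered ring stays within the scatter of both open-chain groups. Among these compounds, the change from the 2-hydroxypropyl of compound 1 gives a 3.3-fold higher number from compound 1 to compound 4 (0.51 log units; beyond the scatter), the first step at this position to pass the scatter, though only modestly. Nothing available explains that step. From the compounds shown here alone, whether an amine or a carboxylic acid on this oxygen would move the number further remains open.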